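A few compounds are considered here, and "the series" means these few. Any claim that something is new, unique, unknown or untested is made for them only; others in the source may bear on it.

Values in a functional assay on A549 cells (Homo sapiens) for inhibition, read by sulforhodamine B assay, with a stated time of 48 h (a higher number here means a weaker inhibitor of growth, a lower number a stronger inhibitor of growth), so far:
Compound 1 `COc1ccc(/C=C/C(=O)C(=Cc2ccc(N(C)C)cc2)C(=O)/C=C/c2ccc(OC)c(OC)c2)cc1OC` gives 2620 nM
Compound 2 `COc1ccc(OC)c(C=C(C(=O)/C=C/c2ccc(O)c(OC)c2)C(=O)/C=C/c2ccc(O)c(OC)c2)c1` gives 670 nM

Compound 2 holds the lower number of the two (670 nM), and the gap to compound 1 (2620 nM) lies beyond the scatter. Compound 3 (`COc1cc(/C=C/C(=O)C(=Cc2cccc(F)c2)C(=O)/C=C/c2ccc(O)c(OC)c2)ccc1O`) alters compound 2 at one place (3-fluorophenyl in place of 2,5-dimethoxyphenyl on a double-bonded chain carbon bound to a double-bonded chain carbon), with 3-fluorophenyl in place of 2,5-dimethoxyphenyl. For the measured compounds named here, no measured pair shows this swap alone, so the data give no direct guide. The rest of compound 2 (670 nM) stays unchanged. In this assay no step beyond the scatter is therefore expected (a 1.0-fold higher number from compound 2 to compound 3 (0.02 log units; within the scatter)). The estimated value for compound 3 is 700 nM with a range from 250 nM to 2000 nM as expected limits.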

Compound 3, concentration for 50% growth inhibition: 360 nM
Compound 3: the middle estimate sits 1.9-fold (0.29 log units) above what was measured; the measured number falls inside the stated range.
By their numbers in this assay, from the lowest: compounds 3 and 2 (each within the scatter of the next); then compound 1.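

In this assay, 3-fluorophenyl in place of 2,5-dimethoxyphenyl on a double-bonded chain carbon bound to a double-bonded chain carbon gives a 1.9-fold lower number from compound 2 to compound 3 (0.27 log units; within the scatter), so the two groups cannot be told apart at this position. The entering group has no hydrogen-bond acceptors and the leaving group has them, yet the number stays within the scatter. Nothing measured here explains this result. On these data alone, how a carboxylic acid or a nitrile on this ring would behave remains open, and so does the effect of simple phenyl at this position.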